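A Methyl Becomes a Methoxy on the Phenyl Ring

A few compounds are considered here, and "the series" means these few. Any claim that something is new, unique, unknown or untested is made for them only; others in the source may bear on it.

Compound 3 `C/C(=N\Nc1nc(-c2ccc(C)cc2)cs1)c1sc(-c2ccccc2)nc1C` is the point of departure. In a toxicity assay on HCT-116 cells (Homo sapiens) for cytotoxicity, read by MTT assay (on this read-out lower numbers stand for stronger inhibition of growth and higher numbers for weaker inhibition of growth), compound 3 gives only the limit > 100 ug/mL, not a number. The two compounds around it sit at the same limit. Compound 2 `C/C(=N\Nc1nc(-c2ccc(Cl)cc2)cs1)c1sc(-c2ccccc2)nc1C` gives the limit > 100 ug/mL in this assay. Compound 1 `COc1ccc(-c2csc(N/N=C(\C)c3sc(C)nc3C)n2)cc1`, which carries a methoxy on its phenyl ring, also gives only the limit > 100 ug/mL. Going by the values given here, the single measured step, a step that the two limits leave unreadable from compound 2 to compound 3, cannot be read in size because of the limit of > 100 ug/mL in this assay, at which 3 of the 3 values shown sit. Compound 4 `COc1ccc(-c2csc(N/N=C(\C)c3sc(-c4ccccc4)nc3C)n2)cc1` differs from compound 3 in one place: methoxy in place of methyl on an aromatic carbon. Among the compounds with values here, no measured step covers this exact change, so nothing points to a readable shift in either direction. Compound 1 shares the methoxy and stands at the limit > 100 ug/mL, which supports the expectation that compound 4 stays there as well. Compound 4 is therefore estimated at 150 ug/mL, between 60 ug/mL and 400 ug/mL. The expected step is a step that the limit leaves unreadable from compound 3 to compound 4, no change beyond the scatter.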

Compound 4, concentration for 50% growth inhibition: > 100 ug/mL
Compound 4 ended at the assay's limit (the forecaster's own chance of this, stated with the estimate: 80%); the middle value lies beyond the limit too.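

Compound 4 joins compound 1, compound 2 and compound 3 at the limit in this assay, so none of its steps to these compounds can be read in size: the limit of > 100 ug/mL in this assay, at which 4 of the 4 values shown sit. The compounds shown leave open which change, if any, would give a readable value.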